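Replacing the 3-cyanophenyl group of compound 3

This account rests on a few compounds, and the source may have more. Where it says the series, first, only, none or still open, it means among the compounds named here.

In an ADME assay on a cell-free system (plasma, Homo sapiens) for protein binding, compound 3 (`CNc1nccc(N2CC[C@H](NC(=O)Nc3cccc(C#N)c3)C2)n1`) gives 94.4% and compound 1 (`CNc1nccc(N2CC[C@H](NC(=O)Nc3ccc(CN(C)C)c(C(F)(F)F)c3)C2)n1`) gives 94.3% as a pair within the scatter of each other. Compound 2 (`CNc1nccc(N2CC[C@H](NC(=O)Nc3cc(OC)cc(OC)c3)C2)n1`) gives 98.1% in the same measurement. The gap between compound 2 and compound 3 lies beyond the scatter, and compound 3 has the larger unbound fraction of that pair.

The next compound is compound 4 (`CNc1nccc(N2CC[C@H](NC(=O)Nc3ccc(C)c(Cl)c3)C2)n1`). It keeps the shared core and has 3-chloro-4-methylphenyl in place of 3-cyanophenyl on an amide-type nitrogen.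

Among the compounds with values here, no two measured compounds differ in one place only, so the size of this change cannot be read directly from the series. Compound 2 at 98.1% shows that an aryl group without a nitrile can reach high binding on this core. Compound 1 at 94.3% goes against any simple reading, as it also has no nitrile yet stays level with compound 3. Within the data shown here, a modest move towards more binding is expected, and the estimated change is a 2.2-fold lower unbound fraction from compound 3 to compound 4 (0.35 log units; beyond the scatter) with only three compounds to support it. The estimate for compound 4 is 97.5% (expected range 95.5% to 98.9%).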

Compound 4, plasma protein binding: 99.3%
Compound 4: the middle estimate sits 3.6-fold (0.55 log units) (unbound fraction) above what was measured, and the stated range ends below it.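

In this assay, within the data shown here, 3-chloro-4-methylphenyl in place of 3-cyanophenyl on an amide-type nitrogen gives an 8.0-fold lower unbound fraction from compound 3 to compound 4 (0.90 log units; beyond the scatter), the first step that can be read at a single place, and it shows that this position alone can shift binding beyond the scatter on the shared core. The two groups match in heavy-atom count and each holds one six-membered aromatic ring of carbon only, so the printed differences are the nitrile and its hydrogen-bond acceptor leaving and the chlorine and methyl entering. Nothing at hand gives a measured reason for the size of this step.

Among these compounds, with only this pair, the contributions of the chlorine, the methyl and the loss of the nitrile cannot be separated. A carboxylic acid or a primary amine on the aryl group at this same place would test whether binding can be brought back down from the level of compound 4 at 99.3% on the this assay scale.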